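The compounds below may be only part of what the source reports. "The series", "measured", "known", "first", "only" and "open" are said of these compounds alone.

Measured compounds in an assay on HEK293 cells for inhibition of Steryl-sulfatase (Homo sapiens), tested at 0.1 uM; on this read-out lower numbers stand for a weaker effect and higher numbers for a stronger effect at the one concentration tested:

Compound 1, `NS(=O)(=O)Oc1ccc2c(c1)CN(C(=O)c1ccc(N3CCC(N4CCCCC4)CC3)cc1)CC2`: compound 1 gives 8.5%
Compound 2, `NS(=O)(=O)Oc1ccc2c(c1)CN(C(=O)c1ccc(N3CCCCC3)cc1)CC2`: compound 2 gives 11.5%
Compound 3, `CN(C)CCN(CCN(C)C)c1cccc(C(=O)N2CCc3ccc(OS(N)(=O)=O)cc3C2)c1`: compound 3 gives 0%

Compound 2 has the highest of the three numbers, but its gap to compound 1 is within the scatter, so the two cannot be ranked; only compound 3, whose number is lower by an amount beyond the scatter, is clearly separated from compound 2. Within the data shown here, the single measured step, a number 3 percentage points higher from compound 1 to compound 2 (within the scatter), concerns a change on a saturated ring carbon and stays within the scatter.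

Compound 4, `CCCN(Cc1ccccc1)c1ccc(C(=O)N2CCc3ccc(OS(N)(=O)=O)cc3C2)cc1`, differs from compound 2 by benzyl(propyl)amino in place of piperidin-1-yl on an aromatic carbon. Among the measured compounds shown here, no measured step concerns a change at that place; the step from compound 1 to compound 2 touches the same group but at a different site, and it was small. Compound 3, which carries open-chain amino substituents on its benzamide, sits at the bottom of the range. All three measured values are low, and nothing indicates that the new group moves the number far in either direction. The step of a number 1.5 percentage points lower from compound 2 to compound 4 (within the scatter) is therefore expected to stay within the scatter. Compound 4 is estimated to give 10%, in the range 0% to 25%.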

Compound 4, a percentage reported as inhibition, at one concentration (the size of the read-out at that concentration, not a potency): 64.8%
For compound 4 the middle estimate is 54.8 percentage points below the measured one, outside the stated range (above it).
By their numbers in this assay, from the lowest: compounds 3, 1 and 2 (each within the scatter of the next, the first and the last beyond it); then compound 4.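

In this assay, among these compounds, this aromatic carbon, para to a large group, proves to be a place where a single change can move the number far: benzyl(propyl)amino in place of piperidin-1-yl comes with a number 53.3 percentage points higher from compound 2 to compound 4 (beyond the scatter), whereas the only earlier step, a number 3 percentage points higher from compound 1 to compound 2 (within the scatter), concerned a saturated ring carbon and stayed within the scatter. The change replaces a six-membered non-aromatic ring with a group carrying a six-membered aromatic ring of carbon only and raises the heavy-atom count, while the hydrogen-bond donor and acceptor counts stay the same and neither group carries a net charge. Nothing available explains the rise.

The compounds shown do not separate the contributions of the benzyl and propyl parts, so it remains open whether dipropylamino, with no aromatic ring, or benzylamino, without the propyl chain, would keep the higher number. They also leave open how a longer chain such as butyl in place of propyl, or a fluorine or methoxy group on the benzyl ring, would change it, and a reading at one concentration gives no potency for compound 4.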